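Moving the nitrile around the benzyl ring

The source may hold more compounds than are shown below. What is called first, only, known or untested is meant among the compounds shown, and "the series" means these compounds.

Compound 1, `O=C(O)c1ccccc1-c1ccc(CCc2ncc(CC3CCOCC3)[nH]2)cc1`, gives 338 nM in an in vitro functional assay on cells for agonist activity at Bombesin receptor subtype-3 (Homo sapiens), read by luminescence and calcium flux; on this read-out lower numbers stand for an effect already at smaller amounts and higher numbers for an effect only at larger amounts of compound.
Compound 2, `N#Cc1ccccc1Cc1cnc(CCc2ccc(-c3ccccc3C(=O)O)cc2)[nH]1`, gives 5480 nM in this assay.
Compound 3, `COc1ccccc1Cc1cnc(CCc2ccc(-c3ccccc3C(=O)O)cc2)[nH]1`, gives 1720 nM in this assay.

Compound 3 holds the second highest of the three numbers. Its nearest neighbour is compound 2, as a 3.2-fold lower number from compound 2 to compound 3 (0.50 log units; beyond the scatter) shows; its furthest is compound 1, as a 5.1-fold higher number from compound 1 to compound 3 (0.71 log units; beyond the scatter) shows. The unmeasured compound 4, `N#Cc1ccc(Cc2cnc(CCc3ccc(-c4ccccc4C(=O)O)cc3)[nH]2)cc1`, differs from compound 3 in one place: 4-cyanophenyl in place of 2-methoxyphenyl on a saturated chain carbon bound to an aromatic carbon.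

Among the compounds with values here, two measured steps bear on this. The closest is a 3.2-fold lower number from compound 2 to compound 3 (0.50 log units; beyond the scatter), which shows that a nitrile in place of a methoxy on the same aromatic carbon gave the higher number, a modest step. The steps of a 16-fold higher number from compound 1 to compound 2 (1.21 log units; beyond the scatter) and a 5.1-fold higher number from compound 1 to compound 3 (0.71 log units; beyond the scatter) show that either aromatic group gave a higher number than oxan-4-yl, the nitrile more so. Within the data shown here, no measured step moves the nitrile to a different carbon of the ring, so that part of the change is uncharted. A modest rise beyond the scatter is therefore expected, with wide uncertainty.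

Compound 4 is estimated at 3000 nM, within a range from 1000 nM to 10000 nM, which is expected to mean a step of a 1.7-fold higher number from compound 3 to compound 4 (0.24 log units; within the scatter).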

Compound 4, half-maximal effective concentration: 5890 nM
Estimate against measurement, compound 4: 2.0-fold (0.29 log units) below, within the range that was stated.
By their numbers in this assay, from the lowest: compound 1; then compound 3; then compounds 2 and 4 (each within the scatter of the next).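

The place of the nitrile on the benzyl ring makes no measurable difference here (a 1.1-fold higher number from compound 2 to compound 4 (0.03 log units; within the scatter)), so 4-cyanophenyl and 2-cyanophenyl cannot be told apart in this assay. The nitrile's disadvantage against the methoxy group therefore appears with the nitrile in either place, although the step to 4-cyanophenyl (a 3.4-fold higher number from compound 3 to compound 4 (0.53 log units; beyond the scatter)) changes both the group and where it sits on the ring, and the large loss against oxan-4-yl also returns with this new group (a 17-fold higher number from compound 1 to compound 4 (1.24 log units; beyond the scatter)). No measurement available here accounts for any of these differences.

The compounds shown do not tell whether a benzyl ring with a different group, such as an amine or a fluorine, would bring the number closer to that of compound 1 (338 nM) or whether a plain, unsubstituted benzyl group would do just as well. They also leave open whether oxan-4-yl does better through being a saturated ring at all, a question that a cyclohexyl group or a piperidine ring, which contains an amine, could help to answer.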